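The source may report more compounds than this note shows. Statements on the series, on what has been measured and on what is new or still open speak of the compounds shown alone.

Measured so far in a physicochemical assay for solubility, read by HPLC, with a stated time of 4 h, at pH 7; on this read-out lower numbers stand for lower solubility and higher numbers for higher solubility:
Compound 1 `C[C@]1(COc2ccc(NC(=O)Nc3ccc(C(F)(F)F)cc3)cc2)Cn2cc([N+](=O)[O-])nc2O1` gives < 1 ug/mL, which is a limit of the assay rather than a number.
Compound 2 `C[C@]1(COc2ccc(S(=O)(=O)N3CCCCC3)cc2)Cn2cc([N+](=O)[O-])nc2O1` gives 13.3 ug/mL.
Compound 3 `Cc1ccc(S(=O)(=O)N2CCN(c3ccc(OC[C@@]4(C)Cn5cc([N+](=O)[O-])nc5O4)cc3)CC2)cc1` gives < 1 ug/mL, again a limit rather than a number.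

Compound 1 therefore stands at the limit of < 1 ug/mL in this assay, at which 2 of the 3 values shown sit, so only a ceiling on its solubility is known, while compound 2 alone gives a measured number. Compound 4 `CC(C)(C)c1ccc(NC(=O)Nc2ccc(OC[C@@]3(C)Cn4cc([N+](=O)[O-])nc4O3)cc2)cc1` differs from compound 1 in one place: tert-butyl in place of trifluoromethyl on an aromatic carbon. Both compounds share the rest of the structure, including the urea. Among the compounds with values here, no measured pair of compounds shows this change, so no size for the step can be read from the data. Compound 4 is expected to stay close to compound 1, with a step that the limit leaves unreadable from compound 1 to compound 4, likely still at the limit. Compound 4 is estimated at 0.7 ug/mL, between 0.2 ug/mL and 2 ug/mL.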

Compound 4, solubility: < 1 ug/mL
Compound 4: only a limit was reported (the forecaster's own chance of this, stated with the estimate: 75%); the middle value lies beyond the limit too.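

Within the data shown here, compound 1 and compound 4 are both reported only as limits, not numbers, and no step between them can be read. Going by these compounds, the true solubility of each, and whether tert-butyl in place of trifluoromethyl shifts it at all, stays open.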